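A few compounds are considered here, and "the series" means these few. Any claim that something is new, unique, unknown or untested is made for them only; others in the source may bear on it.

Measured compounds:
compound 1 `CSc1nc2snc(C)c2n1[C@H]1C[C@H](O)[C@@H](CO)O1` — 30000 nM
compound 2 `CSc1nc2sncc2n1[C@H]1C[C@H](O)[C@@H](CO)O1` — 6000 nM

Among the measured compounds shown here, in a functional assay on KB cells (Homo sapiens) for antiproliferative activity (a lower number here means a stronger inhibitor, a higher number a weaker inhibitor), compound 2 gives the lowest number of the two; its only neighbour is compound 1, and the change a 5.0-fold lower number from compound 1 to compound 2 (0.70 log units; beyond the scatter) is beyond the scatter. For the measured compounds named here, compound 3 `CSc1nc2sncc2n1[C@@H]1O[C@H](CO)[C@@H](O)[C@@H]1O` differs from compound 2 as follows: hydroxy in place of hydrogen on a saturated ring carbon The one measured step concerns a methyl on the aromatic core and says nothing about the saturated ring carbon of the five-membered non-aromatic ring with 1 oxygen, so no measured step bears on this change and no direction can be read from the numbers so far. The expected step of a 1.7-fold higher number from compound 2 to compound 3 (0.22 log units; within the scatter) is therefore placed near zero, with a wide spread to allow a shift in either direction. For compound 3 the estimate in this assay is 10000 nM, between 2000 nM and 50000 nM.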

Compound 3, half-maximal inhibitory concentration: 15000 nM
Compound 3: the middle estimate sits 1.5-fold (0.18 log units) below what was measured; the range from low to high includes it.
By their numbers in this assay, from the lowest: compound 2; then compounds 3 and 1 (each within the scatter of the next).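

In this assay the saturated ring carbon of the five-membered non-aromatic ring with 1 oxygen proves responsive to substitution: hydroxy in place of hydrogen gives a 2.5-fold higher number from compound 2 to compound 3 (0.40 log units; beyond the scatter). Among the compounds shown here, this is the first measured change on that ring, since the earlier step concerned only a methyl on the aromatic core. The step is modest but beyond the scatter, and it runs towards the weaker end, so this hydroxy brings no gain over hydrogen at this position. No accompanying measurement bears on why the number moves.

From the compounds shown here alone, it remains open whether a fluorine, a methoxy or an amine on this ring carbon would move the number the same way as hydroxy. Also open, going by these compounds, is whether the step would keep its size with the methyl present on the aromatic carbon.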